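Shortening the acyl chain from compound 3 to compound 4

The compounds below may be only part of what the source reports. "The series", "measured", "known", "first", "only" and "open" are said of these compounds alone.

Compound 1 `CCCCCCCC(=O)O[C@H]1[C@H](O)[C@H](n2ccc(N)nc2=O)O[C@@H]1CO`: 0.1 ug/mL
Compound 2 `CCCCCCCCCCCCCCCC(=O)O[C@H]1[C@H](O)[C@H](n2ccc(N)nc2=O)O[C@@H]1CO`: 0.24 ug/mL
Compound 3 `CCCCCCCC/C=C\CCCCCCCC(=O)O[C@H]1[C@H](O)[C@H](n2ccc(N)nc2=O)O[C@@H]1CO`: 0.06 ug/mL

Three esters of a shared core were measured in a functional assay on HeLa cells (Homo sapiens) for cytotoxicity, read by cell counting, with a stated time of 48 h; on this read-out higher numbers stand for an effect only at larger amounts of compound and lower numbers for an effect already at smaller amounts. Compound 3 has the lowest of the three numbers, though compound 1 lies within the scatter of it and only compound 2 stands beyond. Compound 4 `CCCCCCCCCCC(=O)O[C@H]1[C@H](O)[C@H](n2ccc(N)nc2=O)O[C@@H]1CO` is not yet measured; it differs from compound 3 by propyl in place of dec-1-en-1-yl on a saturated chain carbon, seven bonds along the chain from a carbonyl carbon. For the measured compounds named here, two measured steps bear on the chain: a 2.4-fold higher number from compound 1 to compound 2 (0.38 log units; beyond the scatter) and a 4.0-fold lower number from compound 2 to compound 3 (0.60 log units; beyond the scatter), while a 1.7-fold lower number from compound 1 to compound 3 (0.22 log units; within the scatter). The chain of compound 4 lies between those of compound 1 and compound 2, so a modest rise from compound 3 is expected, a 2.0-fold higher number from compound 3 to compound 4 (0.30 log units; within the scatter). Compound 4 is therefore estimated at 0.12 ug/mL, with a range from 0.05 ug/mL to 0.3 ug/mL.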

Compound 4, concentration for half-maximal effect: 0.04 ug/mL
Beside the measured number, compound 4's estimate is 3.0-fold (0.48 log units) above it, outside the stated range (below it).
By their numbers in this assay, from the lowest: compounds 4, 3 and 1 (each within the scatter of the next, the first and the last beyond it); then compound 2.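

In this assay, the saturated esters do not change in one direction with chain length: there is a 2.5-fold lower number from compound 1 to compound 4 (0.40 log units; beyond the scatter) and a 6.0-fold lower number from compound 2 to compound 4 (0.78 log units; beyond the scatter), so compound 4 has the lowest number among compounds 1, 2 and 4. Nor does a low number depend on dec-1-en-1-yl, since propyl in its place gives a 1.5-fold lower number from compound 3 to compound 4 (0.18 log units; within the scatter). Nothing available here explains this behaviour. Still open, from the compounds shown here alone, is how sharply the number depends on the length of a saturated chain, and whether an amine or a carboxylic acid at the chain end would preserve it.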